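Swapping the ring on the piperidine nitrogen substituent

The compounds below may be only part of what the source reports. "The series", "measured", "known", "first", "only" and "open" are said of these compounds alone.

Measured compounds in an assay on isolated protein for activation of cGMP-dependent protein kinase 1 (Homo sapiens), read by ADP-Glo, with stated times of 120 min and 40 min; on this read-out higher numbers stand for an effect only at larger amounts of compound and lower numbers for an effect already at smaller amounts:
Compound 1 `Clc1cc(Cl)cc(CO[C@H]2CCCN(Cc3cccnc3)[C@H]2c2ccccc2)c1` gives 112000 nM.
Compound 2 `OC[C@@H](O[C@H]1CCCN(Cc2cccc3nonc23)[C@H]1c1ccccc1)c1cc(Cl)cc(Cl)c1` gives 8000 nM.
Compound 3 `Clc1cc(Cl)cc(CO[C@H]2CCCN(Cc3nccs3)[C@H]2c2ccccc2)c1` gives only a limit of the assay, > 200000 nM.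

Among the two numbers actually read, compound 2 stands lowest; the nearest is compound 1, and the gap between them is beyond the scatter. The step to compound 3 is known only as a limit.

Compound 4 `O=C(O)c1cncc(CN2CCC[C@H](O[C@H](CO)c3cc(Cl)cc(Cl)c3)[C@@H]2c2ccccc2)c1` differs from compound 2 in one place: a group of 9 heavy atoms (6 carbon, 1 nitrogen, 2 oxygen; one six-membered aromatic ring with 1 hetero atom) in place of a group of 9 heavy atoms (6 carbon, 2 nitrogen, 1 oxygen; one five-membered aromatic ring with 3 hetero atoms, one six-membered aromatic ring of carbon only), on a saturated chain carbon bound to an amine nitrogen in a ring.

Among the compounds with values here, only one measured step touches the same place: an at least 1.7-fold higher number from compound 1 to compound 3 (0.25 log units; that floor lies within the scatter), and that step is known only through (the limit of > 200000 nM in this assay, at which 1 of the 3 values shown sits). Its floor sits within the scatter, so it gives no firm size, but it points, if anywhere, toward higher numbers when the aromatic group at that position is exchanged.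

Compound 4 is therefore expected to lie somewhat higher than compound 2, as an expected 2.0-fold higher number from compound 2 to compound 4 (0.30 log units; within the scatter). Compound 4 is estimated at 16000 nM in this assay, with a range from 4000 nM to 64000 nM.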

Compound 4, half-maximal effective concentration in the cGMP-dependent protein kinase 1 assay: 34000 nM
Compound 4: middle estimate off by 2.1-fold (0.33 log units), on the low side; the measured number falls inside the stated range.
By their numbers in the cGMP-dependent protein kinase 1 assay, from the lowest: compound 2; then compound 4; then compound 1. At a limit, above all of these: compound 3.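

In the cGMP-dependent protein kinase 1 assay, placing 5-carboxypyridin-3-yl on the saturated chain carbon bound to the ring amine nitrogen gives a 4.3-fold higher number from compound 2 to compound 4 (0.63 log units; beyond the scatter). Unlike the earlier step at this place, which ended at a limit, this exchange has a size that can be read, and it shows that a change here can move the number beyond the scatter while compound 4 still gives a reading. In a physicochemical assay for solubility, read by HPLC, with a stated time of 24 h, at pH 7 (a higher number here means a more soluble compound, a lower number a less soluble compound), compound 2 gives 154000 nM and compound 4 gives 74000 nM, so the lower number falls to compound 4, again beyond the scatter.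

Going by these compounds, what stays open is how much of the step in the cGMP-dependent protein kinase 1 assay belongs to the carboxylic acid rather than to the pyridine ring that carries it. An amide or an aminomethyl group in place of that acid, on the core of compound 4, also remains untested among the compounds shown here.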